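The source may hold more compounds than are shown below. What is called first, only, known or untested is meant among the compounds shown, and "the series" means these compounds.

Measured in a functional assay on THP-1 cells (Homo sapiens) for inhibition, read by sulforhodamine B assay, with a stated time of 48 h, tested at 50 uM; on this read-out higher numbers stand for more inhibition of growth at the one concentration tested and lower numbers for less inhibition of growth:
- compound 1 `COc1ccc(/C=C/C(=O)/C=C/c2ccc(OCc3cn(CCCCOc4cc(=O)oc5ccccc45)nn3)c(OC)c2)cc1OC`: 59%
- compound 2 `COc1cc(/C=C/C(=O)/C=C/c2ccccc2)ccc1OCc1cn(CCCCOc2cc(=O)oc3ccccc23)nn1`: 36%
- compound 3 `COc1ccc(/C=C/C(=O)/C=C/c2ccc(OCc3cn(CCCCCOc4cc(=O)oc5ccccc45)nn3)c(OC)c2)cc1`: 39%

Compound 2, at 36%, lies within the scatter of compound 3, at 39%. It stands clearly under compound 1, and the gap is a number 23 percentage points lower from compound 1 to compound 2 (beyond the scatter). The next compound in the series is compound 4 `COc1cc(/C=C/C(=O)/C=C/c2ccco2)ccc1OCc1cn(CCCCOc2cc(=O)oc3ccccc23)nn1`, not yet measured. Its structure departs from that of compound 2 in one place: furan-2-yl in place of phenyl on a double-bonded chain carbon bound to a double-bonded chain carbon. In words, furan-2-yl stands in place of phenyl on a double-bonded chain carbon bound to a double-bonded chain carbon.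

Among the compounds with values here, only one measured step touches this same place, and it is a number 23 percentage points lower from compound 1 to compound 2 (beyond the scatter), with phenyl in place of 3,4-dimethoxyphenyl. That step shows that a change here can move the number in this assay beyond the scatter. However, it removes two methoxy groups, and no measured compound carries furan-2-yl, so the data give no direct guide to this exchange. A smaller change than that one is therefore expected, with a slight rise at most and no clear direction. The expected step is a number 4 percentage points higher from compound 2 to compound 4 (within the scatter). For compound 4 the estimated value is 40%, with an expected range from 24% to 58%.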

Compound 4, percent growth inhibition at one concentration: 49%
Beside the measured number, compound 4's estimate is 9 percentage points below it; measured number inside the range.
By their numbers in this assay, from the lowest: compounds 2, 3, 4 and 1 (each within the scatter of the next, the first and the last beyond it).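

In this assay, the change on the double-bonded chain carbon bound to a double-bonded chain carbon shows that this position responds to the kind of ring and not only to the loss of methoxy groups: furan-2-yl in place of phenyl gives (a number 13 percentage points higher from compound 2 to compound 4 (beyond the scatter)). The earlier step at this place, from 3,4-dimethoxyphenyl to phenyl, could not show this, yet the unsubstituted furan-2-yl ring gives (a number 10 percentage points lower from compound 1 to compound 4 (within the scatter)), so here the two methoxy groups are not required for a number within the scatter of that of compound 1. Furan-2-yl differs from phenyl in ring size and in carrying one hydrogen-bond acceptor, but no evidence is available to tie the step to either difference or to any other cause.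

Going by these compounds, it remains open whether thiophen-2-yl, pyridin-3-yl or a phenyl ring carrying an amine or a carboxylic acid would behave like furan-2-yl at this place. On these data alone, it also remains open whether the furan-2-yl step would persist on the pentyl-linked chain of compound 3, and each number here comes from a single tested concentration, so full concentration responses are still lacking.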